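This account rests on a few compounds, and the source may have more. Where it says the series, first, only, none or still open, it means among the compounds named here.

Working notes on the series in an assay (Rattus norvegicus) for inhibition of Fatty-acid amide hydrolase 1 (Homo sapiens); a higher number here means a weaker inhibitor, a lower number a stronger inhibitor. Compound 3 `N#Cc1ccccc1-c1cnc(C(=O)CCCCCCc2ccccc2)o1` gives 130 nM, the lowest number of the three measured; compound 1 `Nc1ccccc1-c1cnc(C(=O)CCCCCCc2ccccc2)o1` gives 750 nM and compound 2 `O=C(CCCCCCc1ccccc1)c1ncc(-c2ccccc2C(=O)C(F)(F)F)o1` gives 5000 nM. The steps among them are a 5.8-fold lower number from compound 1 to compound 3 (0.76 log units; beyond the scatter), a 6.7-fold higher number from compound 1 to compound 2 (0.82 log units; beyond the scatter) and a 38-fold lower number from compound 2 to compound 3 (1.59 log units; beyond the scatter). Compound 4 `O=C(CCCCCCc1ccccc1)c1ncc(-c2cccc(O)c2)o1` differs from compound 3 by 3-hydroxyphenyl in place of 2-cyanophenyl on an aromatic carbon. Going by the values given here, none of the measured steps exchanges cyano for hydroxy, so they bear on the change only indirectly: each swaps the substituent on the phenyl, and each moved this assay beyond the scatter, so the phenyl substituent clearly matters here. Among the measured groups, the amino of compound 1 is the closest counterpart of the entering hydroxy, and compound 1 gives 750 nM, a higher number than compound 3. A higher number than compound 3 is therefore expected, with the step estimated at a 4.6-fold higher number from compound 3 to compound 4 (0.66 log units; beyond the scatter). The estimate for compound 4 is 600 nM, with a range of 150 nM to 2500 nM.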

Compound 4, inhibition constant: 50 nM
Compound 4: the middle estimate sits 12-fold (1.08 log units) above what was measured, and the stated range ends above it.
By their numbers in this assay, from the lowest: compound 4; then compound 3; then compound 1; then compound 2.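

In this assay the 3-hydroxyphenyl group, on the aromatic carbon next to the ring oxygen, gives the lowest number of the four compounds, with a 2.6-fold lower number from compound 3 to compound 4 (0.41 log units; beyond the scatter) and a 15-fold lower number from compound 1 to compound 4 (1.18 log units; beyond the scatter). The amino of compound 1 therefore proved a poor guide to the hydroxy of compound 4, and a nitrile is not needed to reach the low end of this series, although both steps change the group and its place on the phenyl together. Nothing available explains the order of these compounds.

The compounds shown leave open how much of the change comes from the group and how much from its place, which 2-hydroxyphenyl and 3-cyanophenyl would separate. Also open, on these data alone, is whether a methoxy or a carboxylic acid in place of the hydroxy would keep the number of compound 4.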